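Phenyl amide in place of fluorobenzyl amide: series notes

The compounds below may be only part of what the source reports. "The series", "measured", "known", "first", "only" and "open" are said of these compounds alone.

Compound 3 `O=C(/C=C/c1coc2cc(O)ccc2c1=O)NCc1ccc(F)cc1` is the reference point for this step. In a functional assay on A549 cells (Homo sapiens) for inhibition, read by MTT assay, with a stated time of 48 h (on this read-out higher numbers stand for weaker inhibition and lower numbers for stronger inhibition), compound 3 gives > 100000 nM, which is a limit of the assay and not a number. Compound 1 `COc1ccc(CNC(=O)/C=C/c2coc3cc(O)ccc3c2=O)cc1` gives > 100000 nM in this assay, likewise a limit. Compound 2 `COc1ccc2c(=O)c(/C=C/C(=O)NCc3ccc(F)cc3)coc2c1` gives > 100000 nM in this assay, again a limit. The step that the two limits leave unreadable from compound 1 to compound 3 and the step that the two limits leave unreadable from compound 2 to compound 3 cannot be sized because the limit of > 100000 nM in this assay, at which 3 of the 3 values shown sit, leaves both ends of each step unread.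

Compound 4 `O=C(/C=C/c1coc2cc(O)ccc2c1=O)Nc1ccccc1` differs from compound 3 by phenyl in place of 4-fluorobenzyl on an amide-type nitrogen. Neither measured step touches the amide substituent; one changes the fluoro against the methoxy, the other the methyl against hydrogen on the ring oxygen, and both are unreadable. No value in the set places compound 3 inside the readable range. The expected step of a number no higher from compound 3 to compound 4 (the limit leaves the size open) in this assay is therefore an expectation resting on the shared limit alone. Compound 4 is expected at 100000 nM, within a range from 20000 nM to 300000 nM, and will most probably again be reported only as a limit.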

Compound 4, half-maximal inhibitory concentration: 24400 nM
Beside the measured number, compound 4's estimate is 4.1-fold (0.61 log units) above it, and the stated range covers the measured number.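

In this assay, within the data shown here, phenyl in place of 4-fluorobenzyl on the amide-type nitrogen gives an at least 4.0-fold lower number from compound 3 to compound 4 (0.61 log units; beyond the scatter), the first readable step. The changes elsewhere, fluoro against methoxy and methyl against hydrogen on the ring oxygen, remain unreadable, so the amide substituent is the only place shown so far where a change brings a value inside the readable range. The size of the step can be bounded on one side only, because one of its ends is a limit: the limit of > 100000 nM in this assay, at which 3 of the 4 values shown sit.

Going by these compounds, whether the lower number goes with the loss of the fluoro or with the loss of the carbon link to the ring stays open, and a plain benzyl or a 4-fluorophenyl on the same nitrogen would separate the two. Also open, on these data alone, is whether an amine or a carboxylic acid on the phenyl ring would move the number further.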